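The compounds below may be only part of what the source reports. "The series", "measured", "known", "first", "only" and "open" are said of these compounds alone.

In a functional assay on WiDr cells (Homo sapiens) for inhibition, read by sulforhodamine B assay, with a stated time of 48 h (a lower number here means a stronger inhibitor of growth, a higher number a weaker inhibitor of growth), compound 1 (`O=C(CCCCCc1ccccc1)OCC1COCCOCCOCCOCCOCCO1`) gives > 100000 nM, which is a limit of the assay and not a measured number. Compound 2 (`O=C(CCCc1cc2ccccc2[nH]1)OCC1COCCOCCOCCOCCOCCO1`) also stops at a limit in this assay, with > 100000 nM. The step that the two limits leave unreadable from compound 1 to compound 2 therefore cannot be read in size or direction, because both compounds sit at the limit of > 100000 nM in this assay, at which 2 of the 2 values shown sit. Compound 1 thus stands only at a limit among the values shown, with nothing that places it more finely.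

Compound 3 (`O=C(CCCCCCCCCCOc1ccccc1)OCC1COCCOCCOCCOCCOCCO1`) has not yet been measured in this assay. It differs from compound 1 in that (5-phenoxypentyl in place of phenyl on a saturated chain carbon, five bonds along the chain from a carbonyl carbon). For the measured compounds named here, no measured step bears directly on this change, and the only step that exists between measured compounds is the unreadable one just described, so it offers no guide to how large a change to expect or which way it should go. With compound 1 at a limit, the step that the limit leaves unreadable from compound 1 to compound 3 is expected to be none beyond the scatter, and a result that is again only a limit is thought more likely than a number. Compound 3 is expected to give about 150000 nM, within a range from 30000 nM to 1000000 nM.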

Compound 3, concentration for 50% growth inhibition: 66000 nM
For compound 3 the middle estimate is 2.3-fold (0.36 log units) above the measured one; measured number inside the range.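

In this assay, compound 3 is the only compound shown that gives a measured number and not a limit, so this position on the chain can carry a larger group, 5-phenoxypentyl in place of phenyl, and still yield a readable result. On these data alone, the change amounts to an at least 1.5-fold lower number from compound 1 to compound 3 (0.18 log units; that floor lies within the scatter); compound 1 stands at a limit, so this figure is only a floor, and the true size of the step stays unknown. The entering group has 12 heavy atoms against 6 and brings 1 hydrogen-bond acceptor where phenyl has 0, but this single step cannot separate the extra chain from the added oxygen.

The step from compound 1 to compound 2 cannot be read, and limits still make up most of what is shown: the limit of > 100000 nM in this assay, at which 2 of the 3 values shown sit. As far as these compounds go, it remains open whether an all-carbon chain in place of the phenoxypentyl group, a longer chain, or an amine or a carboxylic acid at the end of the chain would lower the number further.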